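The source may report more compounds than this note shows. Statements on the series, on what has been measured and on what is new or still open speak of the compounds shown alone.

Measured so far in a functional assay on CWR22R cells (Homo sapiens) for antiproliferative activity, read by propidium iodide staining, with a stated time of 96 h; a higher number here means a weaker inhibitor, a lower number a stronger inhibitor:
Compound 1 `CC(O)(COc1ccc(S(F)(F)(F)(F)F)cc1)C(=O)Nc1ccc(C(F)(F)F)cc1`: 12900 nM
Compound 2 `CC(O)(CS(=O)(=O)c1cccc(S(F)(F)(F)(F)F)c1)C(=O)Nc1ccc(S(F)(F)(F)(F)F)cc1`: 39900 nM

Of the two, compound 2 has the higher number and is therefore the weaker inhibitor, with a gap to compound 1 that lies beyond the usual scatter of repeated measurements. These two compounds differ in more than one place, so their gap cannot be pinned on any single part of the structure.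

The next compound is compound 3 `CC(O)(CS(=O)(=O)c1cccc(C(F)(F)F)c1)C(=O)Nc1ccc(S(F)(F)(F)(F)F)cc1`, which differs from compound 2 in one group only: a group of 4 heavy atoms (1 carbon, 3 fluorine; no ring) in place of a group of 6 heavy atoms (5 fluorine, 1 sulfur; no ring), on an aromatic carbon. The rest of the molecule stays the same. Among the compounds with values here, no measured pair isolates this kind of swap, so the data do not show its size directly. Within the data shown here, the only close reference is compound 2 at 39900 nM. In this assay, no change beyond the scatter is expected, with at most a slight drift towards a lower number. The expected move, a 1.3-fold lower number from compound 2 to compound 3 (0.12 log units; within the scatter), is small. The estimate for compound 3 is 30000 nM, with an expected range from 11000 nM to 70000 nM.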

Compound 3, half-maximal inhibitory concentration: 23800 nM
Compound 3: middle estimate off by 1.3-fold (0.10 log units), on the high side, and the stated range covers the measured number.
By their numbers in this assay, from the lowest: compounds 1, 3 and 2 (each within the scatter of the next, the first and the last beyond it).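

On this aromatic carbon, meta to a large group, the swap of the group of 6 heavy atoms (5 fluorine, 1 sulfur) for trifluoromethyl can now be read directly: in this assay it is a 1.7-fold lower number from compound 2 to compound 3 (0.22 log units; within the scatter) and so cannot be told apart from the noise of repeating the measurement. For this one pair, with the rest of the molecule unchanged, the two groups therefore give numbers that this assay does not separate, even though one group has more heavy atoms than the other. Nothing measured here explains why the two groups read so much alike.

The compounds shown leave open how a group of a different kind on this carbon, such as an amine, a carboxylic acid or a longer carbon chain, would read in this assay. They also leave open whether the same swap would give a step of similar size elsewhere in the molecule, or on the core of compound 1.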